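The source may report more compounds than this note shows. Statements on the series, on what has been measured and on what is new or still open speak of the compounds shown alone.

Compound 1 `Cc1nsc2[nH]cnc12` — 20000 nM
Compound 2 `CSc1nc2c(C)nsc2[nH]1` — 60000 nM
Compound 3 `Cc1nsc2ncn([C@H]3C[C@H](O)[C@@H](CO)O3)c12` — > 100000 nM (a limit, not a number)

All values come from a functional assay on KB cells (Homo sapiens) for antiproliferative activity; on this read-out lower numbers stand for stronger inhibition and higher numbers for weaker inhibition. In this assay compound 1 gives 20000 nM. Compound 2 carries the change methylsulfanyl in place of hydrogen on an aromatic carbon and in this assay compound 2 gives 60000 nM, the step being a 3.0-fold higher number from compound 1 to compound 2 (0.48 log units; beyond the scatter). For compound 3 this assay reports only a limit, > 100000 nM. The difference between the core of compound 1 and the core of compound 3 is not broken down here.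

Compound 4 `CSc1nc2snc(C)c2n1[C@H]1C[C@H](O)[C@@H](CO)O1` stands to compound 3 as compound 2 stands to compound 1: methylsulfanyl in place of hydrogen on an aromatic carbon. The two places are not worded alike; in compound 4 the carbon is also next to the ring atom that bears a group of 8 heavy atoms, so this is the same kind of change, not the same change. Compound 3 already sits at the limit of > 100000 nM in this assay, at which 1 of the 3 values shown sits. Compound 4 is expected to stay beyond that limit, with an expected step that the limit leaves unreadable from compound 3 to compound 4, because the step of a 3.0-fold higher number from compound 1 to compound 2 (0.48 log units; beyond the scatter) raised the number from an already weak start. Compound 4 is therefore estimated at 300000 nM, within 100000 nM to 1000000 nM.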

Compound 4, half-maximal inhibitory concentration: 30000 nM
Compound 4: middle estimate off by 10-fold (1.00 log units), on the high side; measured number outside the range, below it.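

In this assay, methylsulfanyl in place of hydrogen on an aromatic carbon gives an at least 3.3-fold lower number from compound 3 to compound 4 (0.52 log units; beyond the scatter), so on this core the change goes with a lower number. The direction of the change does not carry over from one core to the other: the same change on two cores in this assay, a 3.0-fold higher number (0.48 log units; beyond the scatter) from compound 1 to compound 2 and an at least 3.3-fold lower number (0.52 log units; beyond the scatter) from compound 3 to compound 4, at least 10-fold (1.00 log units) apart, beyond the scatter of two such steps

Compound 3 gives > 100000 nM, a limit and not a number, so this step has a bound and no exact size, and two pairs do not show what in the cores goes with the reversal.

Still open, as far as these compounds go, is whether the reversal holds for other groups on this aromatic carbon, such as an amine or a longer alkylsulfanyl chain. Also open, from the compounds shown here alone, is how the same change behaves when the group of 8 heavy atoms gives way to something smaller, such as an ethyl chain.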